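Carboxymethyl Replaces a Larger Group on an Amide-Type Nitrogen

A few compounds are considered here, and "the series" means these few. Any claim that something is new, unique, unknown or untested is made for them only; others in the source may bear on it.

In a functional assay on HeLa cells (Homo sapiens) for antiproliferative activity, read by MTT assay, with a stated time of 48 h (a lower number here means a stronger inhibitor, a higher number a weaker inhibitor), compound 1 `COC(=O)[C@H](C)NC(=O)c1ccc(Oc2nc3ccccc3nc2NC(C)(C)C)cc1` gives 55200 nM and compound 2 `CC[C@@H](C)[C@H](NC(=O)c1ccc(Oc2nc3ccccc3nc2NC(C)(C)C)cc1)C(=O)OC` gives 31900 nM, which is a 1.7-fold lower number from compound 1 to compound 2 (0.24 log units; within the scatter). Compound 3 `COC(=O)[C@H](CC(C)C)NC(=O)c1ccc(Oc2nc3ccccc3nc2NC(C)(C)C)cc1` gives > 50000 nM, and this is a limit of the assay, not a number. Compound 4 `CC(C)(C)Nc1nc2ccccc2nc1Oc1ccc(C(=O)NCC(=O)O)cc1` carries carboxymethyl in place of the 1-(methoxycarbonyl)-3-methylbutyl of compound 3 on an amide-type nitrogen (carboxymethyl in place of 1-(methoxycarbonyl)-3-methylbutyl on an amide-type nitrogen). Two measured steps offer a guide, though neither includes a change this large: a 1.7-fold lower number from compound 1 to compound 2 (0.24 log units; within the scatter) and an at least 1.5-fold higher number from compound 2 to compound 3 (0.19 log units; that floor lies within the scatter). Both stay within the scatter, so no clear shift beyond the scatter is expected. The estimated step is a step that the limit leaves unreadable from compound 3 to compound 4. Compound 4 is expected near 60000 nM, with an estimated range from 25000 nM to 150000 nM.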

Compound 4, half-maximal inhibitory concentration: > 50000 nM
Compound 4: a limit, no number; the forecaster's own chance of this, stated with the estimate: 55%; the middle value is on the limit's open side.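

In this assay compound 4 gives > 50000 nM, which is a limit of the assay and not a number. With carboxymethyl on the amide-type nitrogen, the change gives an at least 1.5-fold higher number from compound 2 to compound 4 (0.19 log units; that floor lies within the scatter), so losing both the branched side chain and the methyl ester brings no visible gain in strength. The steps to compound 4 from compound 1 and compound 3 cannot be read because of the assay limit: the limit of > 50000 nM in this assay, at which 2 of the 4 values shown sit.

From the compounds shown here alone, how far compound 4 truly lies from the other compounds stays open. Also open, going by these compounds, is whether an amine or a longer chain ending in a carboxylic acid on this nitrogen would give a readable number.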